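The compounds below may be only part of what the source reports. "The series", "measured", "known", "first", "only" and "open" are said of these compounds alone.

Measured so far in a functional assay on A549 cells (Homo sapiens) for inhibition, read by MTT assay, with a stated time of 48 h; on this read-out higher numbers stand for weaker inhibition and lower numbers for stronger inhibition:

- compound 1, `COc1cc(/C=N/Nc2nc(-c3ccc(C(F)(F)F)cc3)cs2)c(Br)c(Br)c1OC`: 17600 nM
- compound 2, `Fc1ccc(/C=N/Nc2nc(-c3ccc(Br)cc3)cs2)cc1F`: > 100000 nM
- compound 3, `Fc1ccc(/C=N/Nc2nc(-c3ccccc3)cs2)cc1F`: 91400 nM

Compound 1 gives the lowest of the two numbers; its nearest neighbour is compound 3, whose number lies beyond the scatter above it. The value for compound 2 is a limit of this assay, not a number. One of the three values shown sits at the limit of > 100000 nM in this assay, at which 1 of the 3 values shown sits. Compound 2 and compound 3 share a core and differ by hydrogen in place of bromo on an aromatic carbon; this gave an at least 1.0-fold lower number from compound 2 to compound 3 (0.03 log units; that floor lies within the scatter). The difference between the cores of compound 1 and compound 2 is not broken down here.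

Compound 4, `COc1cc(/C=N/Nc2nc(-c3ccc(C(F)(F)F)cc3)cs2)cc(Br)c1OC`, is not yet measured. It differs from compound 1 by hydrogen in place of bromo on an aromatic carbon. The same kind of change was made from compound 2 to compound 3, but the surroundings differ: in compound 2 the bromo sits para to a large group, whereas in compound 1 it sits ortho to a bromo group, ortho to a large group, meta to a methoxy group and para to a methoxy group. For the measured compounds named here, the one measured step of this kind ended within the scatter, and that is the only guide. The step from compound 1 to compound 4 in this assay is therefore expected to be a 1.4-fold higher number from compound 1 to compound 4 (0.15 log units; within the scatter), a small one; this expectation rests on an at least 1.0-fold lower number from compound 2 to compound 3 (0.03 log units; that floor lies within the scatter). Compound 4 is estimated at 25000 nM in this assay, with a likely range from 10000 nM to 70000 nM.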

Compound 4, half-maximal inhibitory concentration: 18300 nM
For compound 4 the middle estimate is 1.4-fold (0.14 log units) above the measured one, and the stated range covers the measured number.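

In this assay, hydrogen in place of bromo on the aromatic carbon that is ortho to a bromo group, ortho to a large group, meta to a methoxy group and para to a methoxy group gives a 1.0-fold higher number from compound 1 to compound 4 (0.02 log units; within the scatter). Set beside the same change on the other core, the two steps read: the same change on two cores in this assay, an at least 1.0-fold lower number (0.03 log units; that floor lies within the scatter) from compound 2 to compound 3 and a 1.0-fold higher number (0.02 log units; within the scatter) from compound 1 to compound 4; the limit leaves it open whether they differ

For the compounds shown here, the value of compound 2, > 100000 nM, is a limit of the assay and not a number; the size of the step on that core therefore stays unknown, and the comparison shows only that on the core of compound 1 this change leaves the number within the scatter, not that the change carries over unaltered from one core to another.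

Still open, on these data alone, is whether a group other than bromo or hydrogen on this aromatic carbon, such as an amine or a carboxylic acid, would move the number beyond the scatter. Going by these compounds alone, no compound has been measured in which the remaining bromo group of compound 4 is taken away. Within the data shown here, no compound has been measured with a longer chain in place of either methoxy group on the same ring.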